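Series notes: pyrazoline amides, step from compound 3 to 4

The source may report more compounds than this note shows. Statements on the series, on what has been measured and on what is new or still open speak of the compounds shown alone.

Measured so far:
compound 1 `CCC(=O)N1N=C(c2ccc(C)cc2)CC1c1ccc(C)cc1` — 100000 nM
compound 2 `CCC(=O)N1N=C(c2ccc(OC)cc2)CC1c1ccccc1` — 63100 nM
compound 3 `CCC(=O)N1N=C(c2ccc(OC)cc2)CC1c1ccc(Cl)cc1` — 832 nM

In an assay on isolated protein for inhibition of Amine oxidase [flavin-containing] A (Bos taurus) (a lower number here means a stronger inhibitor, a higher number a weaker inhibitor), compound 3 gives 832 nM and stands lowest of the three numbers; compound 2 sits a long way above it, and compound 1 further still. Among the measured compounds shown here, the only single-point step measured so far is a 76-fold lower number from compound 2 to compound 3 (1.88 log units; beyond the scatter), a large effect for one added atom.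

Compound 4 `CCC(=O)N1N=C(c2ccc(OC)cc2)CC1c1ccc(C)cc1` differs from compound 3 by methyl in place of chloro on an aromatic carbon. For the measured compounds named here, no measured pair isolates methyl against chloro at this position. Compound 1 carries a methyl on the same ring but also differs in the other ring, so its value of 100000 nM bears only loosely. The step from compound 2 to compound 3 shows how much the chloro is worth; whether a methyl recovers part of that is not known from these numbers.

Compound 4 is therefore expected to lie between compound 3 and compound 2, with the step of a 9.6-fold higher number from compound 3 to compound 4 (0.98 log units; beyond the scatter) expected in the weaker direction. The estimate for compound 4 in this assay is 8000 nM, range 2000 nM to 40000 nM.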

Compound 4, half-maximal inhibitory concentration: 7240 nM
Beside the measured number, compound 4's estimate is 1.1-fold (0.04 log units) above it, and the stated range covers the measured number.
By their numbers in this assay, from the lowest: compound 3; then compound 4; then compounds 2 and 1 (each within the scatter of the next).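

In this assay methyl in place of hydrogen gives an 8.7-fold lower number from compound 2 to compound 4 (0.94 log units; beyond the scatter) at this position, whereas methyl in place of chloro gives an 8.7-fold higher number from compound 3 to compound 4 (0.94 log units; beyond the scatter) in the opposite direction. A gain at this position is therefore not unique to chloro, although methyl captures only part of what chloro gives. With the 4-methylphenyl group held fixed, methoxy in place of methyl on the other aromatic ring gives a 14-fold lower number from compound 1 to compound 4 (1.14 log units; beyond the scatter) as the first single-change step read at that site.

Still open, on these data alone, is how an amine, a carboxylic acid or a longer chain in place of chloro or methyl would read at this position. Also open, as far as these compounds go, is whether the methoxy step holds with chloro in place of methyl. No supporting data on these compounds account for the size of any of these steps.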